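This account rests on a few compounds, and the source may have more. Where it says the series, first, only, none or still open, it means among the compounds named here.

Working notes on the series. Going by the values given here, in a functional assay on MCF7 cells (Homo sapiens) for cytotoxicity, read by MTT assay, with a stated time of 24 h (on this read-out higher numbers stand for weaker inhibition of growth and lower numbers for stronger inhibition of growth), compound 1 `COc1ccc(/C=C/C(=O)c2ccc(OCC=C(C)C)cc2O)cc1` gives 97500 nM, the only actual number so far. Compound 2 `COc1cccc(/C=C/C(=O)c2ccc(OCC=C(C)C)cc2O)c1OC` reads > 100000 nM, which is a limit of this assay and not a number. Compound 3 `COc1ccc(/C=C/C(=O)c2ccc(OCC=C(C)C)cc2O)cc1OC` keeps the core of compound 1 and carries one change: methoxy in place of hydrogen on an aromatic carbon. In words, this is methoxy in place of hydrogen on an aromatic carbon, ortho to a methoxy group. Among the compounds with values here, no measured pair sizes this change. The expectation in this assay is therefore no step beyond the usual scatter, with neither direction favoured, as compound 1 at 97500 nM already shows only weak growth inhibition. The expected result is a 1.0-fold lower number from compound 1 to compound 3 (0.01 log units; within the scatter), a small estimated change. For compound 3 the estimated value is 95000 nM, with an expected range from 40000 nM to 180000 nM.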

Compound 3, concentration for 50% growth inhibition: > 100000 nM
Compound 3 gave a limit, no number; the forecaster's own chance of this, stated with the estimate: 45%; middle value at least 1.0-fold (0.02 log units) away from the limit.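

In this assay compound 3 reads > 100000 nM, which is a limit of the assay and not a number. Methoxy in place of hydrogen on an aromatic carbon, ortho to a methoxy group, gives an at least 1.0-fold higher number from compound 1 to compound 3 (0.01 log units; that floor lies within the scatter), the first step in the series between compounds that differ in one place, and it brings no measurable gain in inhibition of growth. That step has only a floor and cannot be sized further because compound 3 stands at a limit: the limit of > 100000 nM in this assay, at which 2 of the 3 values shown sit.

As far as these compounds go, whether an amine or a carboxylic acid on the same aromatic carbon would give an actual number in this assay stays open. Also open, from the compounds shown here alone, is whether a hydroxy group in place of the methoxy group already present in compound 1 would move the result beyond the usual scatter.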